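A trifluoromethyl in place of nitrile on the shared core

This account rests on a few compounds, and the source may have more. Where it says the series, first, only, none or still open, it means among the compounds named here.

Compound 3 `N#Cc1cccc(-c2nc(N)c3cc(Cc4ccccc4)sc3n2)c1` gives 222 nM in a functional assay on CHO-K1 cells for antagonist activity at adenosine receptor A1 (Homo sapiens), read by a beta-galactosidase reporter and cAMP accumulation, with stated times of 15 min and 6 h (a lower number here means a stronger inhibitor, a higher number a weaker inhibitor), the lowest of the three numbers recorded. Compound 1 `Nc1nc(-c2ccc(C3CC3)o2)nc2sc(Cc3ccccc3)cc12` gives 861 nM and compound 2 `Nc1nc(C2CCCO2)nc2sc(Cc3ccccc3)cc12` gives 2950 nM; the steps of a 3.9-fold lower number from compound 1 to compound 3 (0.59 log units; beyond the scatter) and a 13-fold lower number from compound 2 to compound 3 (1.12 log units; beyond the scatter) each exchanged the whole group on that aromatic carbon. Compound 4 `Nc1nc(-c2cccc(C(F)(F)F)c2)nc2sc(Cc3ccccc3)cc12` differs from compound 3 by trifluoromethyl in place of cyano on an aromatic carbon. Among the compounds with values here, no measured step swaps only a substituent on a six-membered aromatic ring of carbon only, so the two steps into compound 3 bear on this change only loosely. Since the 3-cyanophenyl gave the lowest number, a change kept within it is expected to cost little. Compound 4 is therefore expected at 400 nM, between 120 nM and 1300 nM. The expected step is a 1.8-fold higher number from compound 3 to compound 4 (0.26 log units; within the scatter).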

Compound 4, inhibition constant: > 1000 nM
Compound 4: a limit, no number (the forecaster's own chance of this, stated with the estimate: 3%); at least 2.5-fold (0.39 log units) between middle value and limit.
By their numbers in this assay, from the lowest: compound 3; then compound 1; then compound 2.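

Exchanging only the nitrile for trifluoromethyl on the aromatic carbon gives an at least 4.5-fold higher number from compound 3 to compound 4 (0.65 log units; beyond the scatter) in this assay. The earlier steps shown here each replaced the whole group on the shared core, whereas this one shows that the number responds to a change of substituent alone, with the 3-substituted phenyl ring kept. The value of compound 4 is a limit and not a number: the limit of > 1000 nM in this assay, at which 1 of the 4 values shown sits.

Going by these compounds, how far past that limit compound 4 lies remains open. So does whether an amine, a carboxylic acid or a methoxy group in this place would match the nitrile.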